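The source may hold more compounds than are shown below. What is called first, only, known or untested is meant among the compounds shown, and "the series" means these compounds.

Measured in a functional assay on HCT-116 cells (Homo sapiens) for inhibition, read by CCK-8 assay, with a stated time of 48 h; on this read-out lower numbers stand for stronger inhibition and higher numbers for weaker inhibition:
- compound 1 `COc1cc(-c2ccnc3cc(-c4ccc(F)cc4)nn23)cc(OC)c1OC`: 5030 nM
- compound 2 `COc1cc(-c2ccnc3cc(-c4ccccc4)nn23)cc(OC)c1OC`: 3880 nM

For the measured compounds named here, compound 2 stands within the scatter of compound 1, and the only measured step, a 1.3-fold lower number from compound 1 to compound 2 (0.11 log units; within the scatter), is hydrogen in place of fluoro on an aromatic carbon. Compound 3 `COc1cc(-c2ccnc3cc(-c4ccc5c(ccn5C)c4)nn23)cc(OC)c1OC` carries 1-methyl-1H-indol-5-yl in place of phenyl on an aromatic carbon. This replaces the whole group that the measured step only touched, so that step gives little guidance on size. A lower number in this assay is expected, though only tentatively. The expected change is a 19-fold lower number from compound 2 to compound 3 (1.29 log units; beyond the scatter). Compound 3 is estimated at 200 nM, with an expected range of 15 nM to 3000 nM.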

Compound 3, half-maximal inhibitory concentration: 39 nM
Beside the measured number, compound 3's estimate is 5.1-fold (0.71 log units) above it, within the range that was stated.
By their numbers in this assay, from the lowest: compound 3; then compounds 2 and 1 (each within the scatter of the next).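

In this assay, this position on the five-membered aromatic ring with 2 nitrogen responds strongly to a change of the whole group, which the earlier swap of fluoro for hydrogen, within the scatter, did not show. 1-Methyl-1H-indol-5-yl in place of phenyl gives a 99-fold lower number from compound 2 to compound 3 (2.00 log units; beyond the scatter) and in place of 4-fluorophenyl gives a 130-fold lower number from compound 1 to compound 3 (2.11 log units; beyond the scatter) as large steps beyond the scatter. Nothing available explains this gain.

Open, going by these compounds, is whether the N-methyl group matters, as a plain 1H-indol-5-yl would show. Open too, on these data alone, is whether a second ring without nitrogen, such as naphthyl, would serve equally.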